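A few compounds are considered here, and "the series" means these few. Any claim that something is new, unique, unknown or untested is made for them only; others in the source may bear on it.

Measured in an assay on CHO cells for displacement of a labelled ligand from prostaglandin D2 receptor 2 (Homo sapiens), read by scintillation counting; on this read-out higher numbers stand for weaker inhibition and lower numbers for stronger inhibition:
Compound 1 `CN(C)S(=O)(=O)c1cccc(C#Cc2cc(Cl)ccc2OCC(=O)O)c1` gives 14 nM
Compound 2 `Cc1ccc(S(=O)(=O)NC(C)(C)C)cc1C#Cc1cc(Cl)ccc1OCC(=O)O` gives 5 nM

Compound 2 has the lower of these two numbers in this assay, and the gap to compound 1 is beyond the scatter of repeated measurements. Compound 1 and compound 2 differ in two places at once, so their two values alone do not tell how much each place contributes.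

Compound 3 `Cc1ccc(S(=O)(=O)N(C)C)cc1C#Cc1cc(Cl)ccc1OCC(=O)O` keeps the methyl group on the ring of compound 2 but carries the sulfonyl group of compound 1: the change is dimethylamino in place of (tert-butyl)amino on a sulfonyl sulfur. Compound 1 shows that a dimethylsulfamoyl group is compatible with binding, but nothing measured here isolates its effect against the tert-butyl variant. In this assay the step from compound 2 to compound 3 is therefore expected to be small, towards a somewhat higher number but possibly within the scatter, estimated as a 1.8-fold higher number from compound 2 to compound 3 (0.26 log units; within the scatter). Compound 3 is expected to give roughly 9 nM, within a range from 3 nM to 27 nM.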

Compound 3, inhibition constant: 5 nM
The estimate for compound 3 lay 1.8-fold (0.26 log units) above the measured number, within the range that was stated.
By their numbers in this assay, from the lowest: compounds 2 and 3 (each within the scatter of the next); then compound 1.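

In this assay, dimethylamino in place of (tert-butyl)amino on a sulfonyl sulfur gives no change at the digits printed from compound 2 to compound 3 (within the scatter) within the scatter, so at this place the sulfonyl group can lose the hydrogen-bond donor and the tert-butyl group with no measurable change in this assay. Holding the dimethylsulfamoyl group fixed also separates the two differences between compound 1 and compound 2: methyl in place of hydrogen on an aromatic carbon gives a 2.8-fold lower number from compound 1 to compound 3 (0.45 log units; beyond the scatter) and so accounts for a gap beyond the scatter on its own. Nothing available explains why either change has the size it does.

On these data alone, it remains open whether the methyl step would be the same with (tert-butyl)amino on the sulfonyl sulfur. Also open, as far as these compounds go, is how a morpholine on that sulfur, or an ethyl or methoxy group in place of the methyl, would read.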